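Methyl in Place of Hydrogen on an Acetoxy Chain

This account rests on a few compounds, and the source may have more. Where it says the series, first, only, none or still open, it means among the compounds named here.

The measured compounds in an ADME assay on MT4 cells (Homo sapiens) for cytotoxicity, read by MTT assay, with a stated time of 96 h (a higher number here means that more compound is tolerated, a lower number that less compound is tolerated), are these.
Compound 1 `CCC(=O)Oc1ccc2ccc(=O)oc2c1Cc1c(-c2ccccc2)[nH]c2ccccc12` gives > 100000 nM, which is a limit of the assay and not a number.
Compound 2 `CC(=O)Oc1ccc2ccc(=O)oc2c1Cc1c(-c2ccccc2)[nH]c2ccccc12` gives > 100000 nM, likewise a limit.
Within the data shown here, compound 3 `CC(=O)Oc1ccc2c(C)cc(=O)oc2c1Cc1c(C)[nH]c2ccccc12` gives 41000 nM, the only plain number among the three.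

Compound 1 and compound 2 differ by one change, (methyl in place of hydrogen on a saturated chain carbon bound to a carbonyl carbon). Both values sit at the limit of > 100000 nM in this assay, at which 2 of the 3 values shown sit, so the step that the two limits leave unreadable from compound 2 to compound 1 cannot be sized from these two compounds alone.

Compound 3 carries a different core; the difference between the core of compound 3 and the core of compound 2 is not broken down here. The unmeasured compound 4 `CCC(=O)Oc1ccc2c(C)cc(=O)oc2c1Cc1c(C)[nH]c2ccccc12` is compound 3 with the same change applied, (methyl in place of hydrogen on a saturated chain carbon bound to a carbonyl carbon), at the very same place.

Since the earlier step is unreadable, the expectation for the step from compound 3 to compound 4 in this assay rests only on compound 3 giving 41000 nM. Compound 1 and compound 2 add no readable size, as each of them shows only a limit of the assay. The step is expected to be a 1.3-fold higher number from compound 3 to compound 4 (0.13 log units; within the scatter). Compound 4 is therefore estimated at 55000 nM, between 20000 nM and 150000 nM.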

Compound 4, half-maximal cytotoxic concentration: 31000 nM
Estimate against measurement, compound 4: 1.8-fold (0.25 log units) above; the measured number falls inside the stated range.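

In this assay, the change from acetoxy to propanoyloxy gives a 1.3-fold lower number from compound 3 to compound 4 (0.12 log units; within the scatter), so on this core the added methyl leaves a difference no larger than repeated measurements of the same compound can show. The same change on the other core, from compound 2 to compound 1, cannot be read, since each of those two compounds gives a limit of the assay and not a number: the limit of > 100000 nM in this assay, at which 2 of the 4 values shown sit. The series therefore holds one readable step on one core, and it does not show whether the change acts alike on both cores, nor that a small step would carry over to any other core.

The compounds shown leave open what a longer chain such as butanoyloxy, or a chain carrying an amine or a carboxylic acid, would do to the tolerated concentration. They also leave open whether any such group would bring the core of compound 1 and compound 2 off the limit, which would give a second step to set against the first.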